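The compounds below may be only part of what the source reports. "The series", "measured", "known", "first", "only" and "open" are said of these compounds alone.

Of the compounds shown here, three sharing one core have been tested in an ADME assay on HEK-293T cells (Homo sapiens) for cytotoxicity, read by MTT assay, with a stated time of 3 days; a higher number here means that more compound is tolerated, a lower number that less compound is tolerated. Compound 1 (`CC(C)OC(=O)COC(=O)c1ccc([N+](=O)[O-])o1`) gives > 100000 nM, which is a limit and not a number. Compound 2 (`O=C(COC(=O)c1ccc([N+](=O)[O-])o1)NC1CCc2ccccc21`) also gives a limit, > 100000 nM. Compound 3 (`CC(C)(C)N(Cc1ccc([N+](=O)[O-])cc1)C(=O)COC(=O)c1ccc([N+](=O)[O-])o1`) gives a limit as well, > 100000 nM, and so it stands with the other two at the limit of > 100000 nM in this assay, at which 3 of the 3 values shown sit. Compound 4 (`CC(C)(C)N(Cc1cccc(C(F)(F)F)c1)C(=O)COC(=O)c1ccc([N+](=O)[O-])o1`) has not yet been measured. It has 3-(trifluoromethyl)phenyl in place of 4-nitrophenyl on a saturated chain carbon bound to an amide-type nitrogen. Among the compounds with values here, no measured pair shows the size of such a change, so no step beyond the scatter is expected in this assay, in either direction. The expected step is a number no higher from compound 3 to compound 4 (the limit leaves the size open). Compound 4 is estimated at 100000 nM, within a range of 35000 nM to 200000 nM.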

Compound 4, half-maximal cytotoxic concentration: 68000 nM
For compound 4 the middle estimate is 1.5-fold (0.17 log units) above the measured one, within the range that was stated.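

In this assay compound 4 is the first compound shown with a real number rather than a limit: the limit of > 100000 nM in this assay, at which 3 of the 4 values shown sit.

Putting 3-(trifluoromethyl)phenyl in place of 4-nitrophenyl on a saturated chain carbon bound to an amide-type nitrogen gives an at least 1.4-fold lower number from compound 3 to compound 4 (0.16 log units; that floor lies within the scatter). Within the data shown here, this is the first step that can be read at this place, but it has only a floor, so it shows no change beyond the scatter.

From the compounds shown here alone, how large the step really is remains open. So does what a plain phenyl, a carboxylic acid or an amine at this place would give.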